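From 3-hydroxypropyl to 2-carbamoylethyl on sulfur

A few compounds are considered here, and "the series" means these few. Any claim that something is new, unique, unknown or untested is made for them only; others in the source may bear on it.

In a functional assay on HT cells (Homo sapiens) for antiproliferative activity, read by fluorescence, with a stated time of 72 h (a lower number here means a stronger inhibitor of growth, a higher number a weaker inhibitor of growth), compound 1 `CC(C)c1n[nH]c2c(NCc3ccc(-c4ccccn4)cc3)nc(SCCN)nc12` gives 22 nM, compound 2 `CC(C)c1n[nH]c2c(NCc3ccc(-c4ccccn4)cc3)nc(SC(C)C(C)O)nc12` gives 190 nM and compound 3 `CC(C)c1n[nH]c2c(NCc3ccc(-c4ccccn4)cc3)nc(SCCCO)nc12` gives 109 nM. Compound 3 therefore stands with the two higher numbers of the set: a 1.7-fold lower number from compound 2 to compound 3 (0.24 log units; within the scatter) lies within the scatter, while a 5.0-fold higher number from compound 1 to compound 3 (0.70 log units; beyond the scatter) lies beyond it.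

Compound 4 `CC(C)c1n[nH]c2c(NCc3ccc(-c4ccccn4)cc3)nc(SCCC(N)=O)nc12` carries carbamoyl in place of hydroxymethyl on a saturated chain carbon, two bonds along the chain from a sulfur. Among the measured compounds shown here, no measured step involves carbamoyl, so the evidence is indirect. Both steps away from the 2-aminoethyl group of compound 1 were modest, an 8.6-fold higher number from compound 1 to compound 2 (0.94 log units; beyond the scatter) and a 5.0-fold higher number from compound 1 to compound 3 (0.70 log units; beyond the scatter). For the measured compounds named here, compound 4 also lacks that group, and the one step between chains without it, a 1.7-fold lower number from compound 2 to compound 3 (0.24 log units; within the scatter), stayed within the scatter. The reference is therefore compound 3, and no change beyond the scatter is expected. The step expected in this assay is a 1.1-fold lower number from compound 3 to compound 4 (0.04 log units; within the scatter). Compound 4 is estimated at 100 nM, with an expected range of 40 nM to 260 nM.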

Compound 4, concentration for 50% growth inhibition: 120 nM
Estimate against measurement, compound 4: 1.2-fold (0.08 log units) below; low and high end bracket the measured number.
By their numbers in this assay, from the lowest: compound 1; then compounds 3, 4 and 2 (each within the scatter of the next).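

In this assay, carbamoyl on a saturated chain carbon, two bonds along the chain from a sulfur, reads the same as hydroxymethyl at that place (a 1.1-fold higher number from compound 3 to compound 4 (0.04 log units; within the scatter)). The 2-carbamoylethyl chain also stays level with the 2-hydroxy-1-methylpropyl chain (a 1.6-fold lower number from compound 2 to compound 4 (0.20 log units; within the scatter)), so the position accepts an amide end as well as the two alcohol chains. The gap to the 2-aminoethyl chain of compound 1 now holds for a third chain without the amine (a 5.5-fold higher number from compound 1 to compound 4 (0.74 log units; beyond the scatter)), and no measurement here bears on the reason for that gap.

Open, as far as these compounds go, is whether the gap depends on the primary amine itself or on its distance from the sulfur, which a 3-aminopropyl chain or a dimethylamino end would test. From the compounds shown here alone, a carboxylic acid at the chain end also remains open.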